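Series notes: phenyl for methyl at the amine of compound 2

This account rests on a few compounds, and the source may have more. Where it says the series, first, only, none or still open, it means among the compounds named here.

Measured compounds:
compound 1 `CN(C)c1ccc(/C=C/C(=O)c2ccc(N(C)C)cc2O)cc1`: 47900 nM
compound 2 `CCN(CC)CCCOc1ccc(C(=O)/C=C/c2ccc(N(C)C)cc2)c(O)c1`: 47100 nM
compound 3 `COc1ccc(/C=C/C(=O)c2ccc(N(C)C)cc2O)cc1`: 42500 nM

All three numbers come from an assay on isolated protein for inhibition of Amine oxidase [flavin-containing] A (Homo sapiens); a higher number here means a weaker inhibitor, a lower number a stronger inhibitor. Compound 2 stands second highest of the three; compound 1 is the nearest, a step of a 1.0-fold lower number from compound 1 to compound 2 (0.01 log units; within the scatter), and compound 3 the furthest, both gaps within the scatter. Going by the values given here, the only other step in hand, a 1.1-fold lower number from compound 1 to compound 3 (0.05 log units; within the scatter), is likewise within the scatter, so the three measured compounds are indistinguishable in this assay.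

The unmeasured compound 4 is `CCN(CCCOc1ccc(C(=O)/C=C/c2ccc(N(C)C)cc2)c(O)c1)Cc1ccccc1`. It differs from compound 2 by phenyl in place of methyl on a saturated chain carbon bound to an amine nitrogen. Neither measured step bears directly on this position: the steps from compound 1 to compound 2 and from compound 1 to compound 3 change the substituent on the aromatic carbon, and both remained within the scatter. The end of the chain carrying the amine has not been varied so far. With no step beyond the scatter anywhere in the three measured compounds, the expectation for compound 4 is no step beyond the scatter, an expected change of a 1.0-fold lower number from compound 2 to compound 4 (0.02 log units; within the scatter) in this assay. Compound 4 is therefore estimated at 45000 nM, with a range from 20000 nM to 100000 nM.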

Compound 4, half-maximal inhibitory concentration: 82600 nM
Compound 4: the middle estimate sits 1.8-fold (0.26 log units) below what was measured; measured number inside the range.
By their numbers in this assay, from the lowest: compounds 3, 2, 1 and 4 (each within the scatter of the next).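

In this assay, going by these compounds alone, the amine end of the chain is varied for the first time, and phenyl in place of methyl on a saturated chain carbon bound to an amine nitrogen gives a 1.8-fold higher number from compound 2 to compound 4 (0.24 log units; within the scatter). This reads as diethylamino to benzyl(ethyl)amino: a six-membered aromatic ring of carbon only enters at this position, with no step beyond the usual scatter, so this single change does not separate the pair. Within the data shown here, the earlier steps covered only the substituent on an aromatic carbon, so this is the first reading at this end of the chain, and no measurement here accounts for the size of the step.

Open at this position is whether a piperidine, a morpholine or a carboxylic acid in place of the diethylamino group would give a step beyond the scatter in this assay. Equally open, as far as these compounds go, are a longer chain in place of the 3-(diethylamino)propoxy chain and a fluoro or methoxy group on the phenyl ring of the benzyl group, either of which would test whether this end of the molecule can move the number at all.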